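The source may hold more compounds than are shown below. What is called first, only, known or untested is meant among the compounds shown, and "the series" means these compounds.

Of the compounds shown here, three sharing one core have been tested in a functional assay on U-937 cells (Homo sapiens) for cytotoxicity, read by MTT assay, with a stated time of 3 days; on this read-out higher numbers stand for weaker inhibition and lower numbers for stronger inhibition. Compound 1 `N#Cc1c(O)nc(SCc2nc3ccccc3[nH]2)nc1-c1ccccc1`, carrying hydroxy, gives 3.28 nM, and compound 2 `N#Cc1c(Cl)nc(SCc2nc3ccccc3[nH]2)nc1-c1ccccc1`, carrying chloro, gives 4.46 nM. Compound 3 `CNc1nc(SCc2nc3ccccc3[nH]2)nc(-c2ccccc2)c1C#N`, carrying methylamino, gives 19.2 nM, the highest number of the three and beyond the scatter from both others.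

Compound 4 `CCNc1nc(SCc2nc3ccccc3[nH]2)nc(-c2ccccc2)c1C#N` differs from compound 3 by a single change, methyl in place of hydrogen on a saturated chain carbon bound to a nitrogen on an aromatic ring, which turns methylamino into ethylamino. For the measured compounds named here, no measured step covers this change directly. The closest evidence comes from exchanges of the whole group: a 1.4-fold higher number from compound 1 to compound 2 (0.13 log units; within the scatter) stayed within the scatter, while a 5.9-fold higher number from compound 1 to compound 3 (0.77 log units; beyond the scatter) and a 4.3-fold higher number from compound 2 to compound 3 (0.63 log units; beyond the scatter) were modest. The added methyl is a smaller change than those exchanges, so in this assay no step beyond the scatter is expected, with at most a slight lean towards a higher number. The expected outcome is a 1.1-fold higher number from compound 3 to compound 4 (0.06 log units; within the scatter). For compound 4 the estimated value is 22 nM, within an expected range of 9 nM to 55 nM.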

Compound 4, half-maximal inhibitory concentration: 2.63 nM
Beside the measured number, compound 4's estimate is 8.4-fold (0.92 log units) above it; measured number below the stated range.
By their numbers in this assay, from the lowest: compounds 4, 1 and 2 (each within the scatter of the next); then compound 3.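

In this assay, adding one methyl to the methylamino group of compound 3, which gives ethylamino, produces a 7.3-fold lower number from compound 3 to compound 4 (0.86 log units; beyond the scatter), so a change of a single carbon at this place matters as much as the earlier exchanges of the whole group. The ethylamino compound no longer stands apart from the hydroxy and chloro compounds, with a 1.7-fold lower number from compound 2 to compound 4 (0.23 log units; within the scatter) and a 1.2-fold lower number from compound 1 to compound 4 (0.10 log units; within the scatter), so the higher number of compound 3 belongs to methylamino in particular and not to every alkylamino group at this position. Nothing in the data shown explains this sensitivity to one added carbon.

On these data alone, whether a longer chain such as propylamino keeps the number of compound 4 or moves it again remains open. The same holds for the unsubstituted amino group and for branched or ring amines such as isopropylamino or morpholine.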